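Benzimidazolyl acylthioureas and acylureas: halogen swap on the benzyl ring

A few compounds are considered here, and "the series" means these few. Any claim that something is new, unique, unknown or untested is made for them only; others in the source may bear on it.

Measured so far:
compound 1 `O=C(NC(=S)Nc1ccc(Cl)c(-c2nc3ccccc3[nH]2)c1)c1ccc(OCc2ccc(C(F)(F)F)cc2)cc1` — 63900 nM
compound 2 `O=C(NC(=S)Nc1ccc(Cl)c(-c2nc3ccccc3[nH]2)c1)c1ccc(OCc2ccc(Cl)c(Cl)c2)cc1` — 24900 nM
compound 3 `Cc1ccc(NC(=O)NC(=O)c2ccc(OCc3cccc(Cl)c3)cc2)cc1-c1nc2ccccc2[nH]1` — 16000 nM

In a functional assay on SW-620 cells (Homo sapiens) for inhibition, read by MTT assay, with a stated time of 48 h (a higher number here means a weaker inhibitor, a lower number a stronger inhibitor), compound 3 gives 16000 nM, the lowest of the three numbers in hand. Compound 2 gives 24900 nM, which lies within the scatter of compound 3, so the two cannot be told apart on these data. Compound 1 gives 63900 nM, a number well above that of compound 3.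

Compound 4 `Cc1ccc(NC(=O)NC(=O)c2ccc(OCc3cccc(F)c3)cc2)cc1-c1nc2ccccc2[nH]1` is not yet measured. It differs from compound 3 only in the benzyl ring: fluoro in place of chloro on an aromatic carbon.

For the measured compounds named here, the only measured step is a 2.6-fold lower number from compound 1 to compound 2 (0.41 log units; beyond the scatter), which also alters the benzyl substituent, but on a different core and with a different pair of groups, so it bears only loosely on the present change. An exchange of one halogen for another at the same ring position is a smaller change than that one; nothing in hand suggests a large movement in either direction. The expected step is therefore a 1.4-fold higher number from compound 3 to compound 4 (0.14 log units; within the scatter), at most a modest rise in the number, possibly none beyond the scatter.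

Compound 4 is expected to give 22000 nM, with a range of 9000 nM to 55000 nM.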

Compound 4, half-maximal inhibitory concentration: 39600 nM
Compound 4: the middle estimate sits 1.8-fold (0.26 log units) below what was measured, within the range that was stated.
By their numbers in this assay, from the lowest: compounds 3, 2, 4 and 1 (each within the scatter of the next, the first and the last beyond it).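

In this assay, the swap of 3-chlorobenzyl to 3-fluorobenzyl gives a 2.5-fold higher number from compound 3 to compound 4 (0.39 log units; beyond the scatter), so exchanging one halogen for another on this aromatic carbon, meta to a large group, is enough to move the number beyond the scatter. The earlier step, a 2.6-fold lower number from compound 1 to compound 2 (0.41 log units; beyond the scatter), changed a different pair of groups on a different core, whereas this one isolates a single atom at a single position and shows that, of these two halogens, chloro goes with the lower number on this core. No measurement in hand accounts for the size or direction of this step.

The compounds shown leave open whether the order extends beyond these two halogens: an unsubstituted benzyl ring would show whether either halogen lowers or raises the number relative to hydrogen, while bromo or methyl at the same position would test whether the trend continues. From the compounds shown here alone, it also remains open whether the same exchange gives a step of similar direction and size on the acylthiourea core of compound 1 and compound 2.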